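A Dichloro Swap at the Assay Limit

The source may report more compounds than this note shows. Statements on the series, on what has been measured and on what is new or still open speak of the compounds shown alone.

In a functional assay on B16 cells (Mus musculus) for antiproliferative activity, read by MTT assay, with a stated time of 72 h (a lower number here means a stronger inhibitor, a higher number a weaker inhibitor), compound 1 `COc1cc(/C(=C/c2ccc(C)cc2)C(C)O)cc(OC)c1OC` gives > 100000 nM as a limit, not a number. Compound 2 `COc1cc(/C(=C/c2ccc(Cl)cc2)C(C)O)cc(OC)c1OC` gives > 100000 nM as a limit too. Compound 3 `COc1cc(/C(=C/c2ccc(Br)cc2)C(C)O)cc(OC)c1OC` gives > 100000 nM as a limit as well, so it has no number of its own. The whole series rests on the limit of > 100000 nM in this assay, at which 3 of the 3 values shown sit, and nothing more. In compound 4 `COc1cc(/C(=C/c2ccc(Cl)c(Cl)c2)C(C)O)cc(OC)c1OC` 3,4-dichlorophenyl replaces 4-bromophenyl (3,4-dichlorophenyl in place of 4-bromophenyl on a double-bonded chain carbon bound to a double-bonded chain carbon) and the rest matches compound 3. The measured steps that bear on this are a step that the two limits leave unreadable from compound 1 to compound 2 and a step that the two limits leave unreadable from compound 1 to compound 3 and a step that the two limits leave unreadable from compound 2 to compound 3 and none has a readable size. Given a step that the two limits leave unreadable from compound 2 to compound 3 no step beyond the scatter is expected in this assay and the estimated move is a number no higher from compound 3 to compound 4 (the limit leaves the size open) with no firm direction. Compound 4 is estimated at 100000 nM within an expected range of 30000 nM to 200000 nM and will probably report only a limit.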

Compound 4, half-maximal inhibitory concentration: 51500 nM
For compound 4 the middle estimate is 1.9-fold (0.29 log units) above the measured one, and the stated range covers the measured number.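

On this ring, 3,4-dichlorophenyl is the only group shown that gives a number in this assay, while the steps among compound 1, compound 2 and compound 3 cannot be read: the limit of > 100000 nM in this assay, at which 3 of the 4 values shown sit. Set against those limits, the result gives an at least 1.9-fold lower number from compound 2 to compound 4 (0.28 log units; that floor lies within the scatter), an at least 1.9-fold lower number from compound 3 to compound 4 (0.28 log units; that floor lies within the scatter) and an at least 1.9-fold lower number from compound 1 to compound 4 (0.28 log units; that floor lies within the scatter). Each of these is only a floor, so no real difference is established yet, but compound 4 gives later changes a number to be compared with.

Going by these compounds, what a phenyl ring carrying an amine or a carboxylic acid would give in its place stays open.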